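The compounds below may be only part of what the source reports. "The series", "measured", "known", "first", "only" and "open" are said of these compounds alone.

Compounds measured in a functional assay on PC-3 cells (Homo sapiens) for antiproliferative activity, read by MTT assay, with a stated time of 48 h; on this read-out higher numbers stand for weaker inhibition and lower numbers for stronger inhibition:
compound 1 `Cc1cnc(Nc2ccc(S(C)(=O)=O)cc2)nc1Nc1nc2ccc(Cl)cc2s1`, 13400 nM
compound 2 `Cc1ccc2nc(Nc3nc(Nc4ccc(S(N)(=O)=O)cc4)ncc3C)sc2c1`, 2710 nM
compound 3 `Cc1cnc(Nc2ccc(S(N)(=O)=O)cc2)nc1Nc1nc2ccccc2s1`, a limit of the assay, > 50000 nM

Compound 3 stands at the weak end of these three: its result is only a limit, (the limit of > 50000 nM in this assay, at which 1 of the 3 values shown sits), and no number is known for it. Going by the values given here, the one measured step that reaches compound 3 is an at least 18-fold higher number from compound 2 to compound 3 (1.26 log units; beyond the scatter), so the hydrogen in place of the methyl on that aromatic carbon cost a great deal of activity. Compound 4 `Cc1cnc(Nc2ccc(S(N)(=O)=O)cc2)nc1Nc1nc2ccc(Cl)cc2s1` differs from compound 3 by chloro in place of hydrogen on an aromatic carbon, that is, a chloro now occupies the same aromatic carbon that carries the methyl in compound 2 and the chloro in compound 1. Among the compounds with values here, no measured step shows chloro against hydrogen at this place directly, but compound 1, which carries the chloro together with a methylsulfonyl group, gives 13400 nM, a number rather than a limit. Because the loss seen in an at least 18-fold higher number from compound 2 to compound 3 (1.26 log units; beyond the scatter) followed removal of a substituent from this carbon, restoring a substituent there is expected to give a step of about an at least 6.2-fold lower number from compound 3 to compound 4 (0.79 log units; beyond the scatter) back toward stronger inhibition. Compound 4 is therefore estimated at 8000 nM, in a range from 2000 nM to 40000 nM.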

Compound 4, half-maximal inhibitory concentration: 5400 nM
Compound 4: the middle estimate sits 1.5-fold (0.17 log units) above what was measured; measured number inside the range.
By their numbers in this assay, from the lowest: compounds 2 and 4 (each within the scatter of the next); then compound 1. At a limit, above all of these: compound 3.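

In this assay, chloro and hydrogen at this aromatic carbon can now be set directly against each other, with an at least 9.2-fold lower number from compound 3 to compound 4 (0.96 log units; beyond the scatter), while chloro and methyl at the same carbon cannot be told apart, with a 2.0-fold higher number from compound 2 to compound 4 (0.30 log units; within the scatter), so in these compounds a large change follows the loss of either group rather than the exchange of one for the other. Going by these compounds alone, the new compound also gives the first reading at the sulfonyl sulfur with the chloro held in place, where a 2.5-fold lower number from compound 1 to compound 4 (0.39 log units; beyond the scatter) shows a modest gain for amino in place of methyl, so that place matters too, though much less than the presence of a substituent on the aromatic carbon appears to. Compound 3 is known only as a limit of the assay, so the step that reaches it gives a bound and not a size: the limit of > 50000 nM in this assay, at which 1 of the 4 values shown sits.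

From the compounds shown here alone, whether groups such as methoxy, bromo, an amine or a carboxylic acid on this aromatic carbon would match chloro and methyl remains open. Also open, going by these compounds, is whether amino in place of methyl on the sulfonyl sulfur gives a similar step when methyl rather than chloro sits on the aromatic carbon.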